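Side-chain variation on the amino ester: compound 4

A few compounds are considered here, and "the series" means these few. Any claim that something is new, unique, unknown or untested is made for them only; others in the source may bear on it.

Within the data shown here, compound 3 `C[C@H](NC(=O)CN(c1ncnc2c1ncn2C1CCCCO1)C1CC1)C(=O)OCc1ccccc1` gives 53% in a functional assay on the whole organism (Tail, strain ICR) with Mus musculus as the target, in the tail flick test, with a stated time of 60 min, at a dose of 25 umol/kg by the oral route (a lower number here means a weaker effect, a higher number a stronger effect of the compound at the dose given), the highest of the three numbers so far. Compound 2 `O=C(CN(c1ncnc2c1ncn2C1CCCCO1)C1CC1)N[C@@H](CO)C(=O)OCc1ccccc1` gives 46.7%, and compound 1 `C[C@@H](O)[C@H](NC(=O)CN(c1ncnc2c1ncn2C1CCCCO1)C1CC1)C(=O)OCc1ccccc1` gives 28.4%; the steps are a number 18.3 percentage points higher from compound 1 to compound 2 (beyond the scatter), a number 24.6 percentage points higher from compound 1 to compound 3 (beyond the scatter) and a number 6.3 percentage points higher from compound 2 to compound 3 (within the scatter). Compound 4 `CSCC[C@H](NC(=O)CN(c1ncnc2c1ncn2C1CCCCO1)C1CC1)C(=O)OCc1ccccc1` is the next entry: (methylsulfanyl)methyl in place of hydrogen on a saturated chain carbon, two bonds along the chain from an amide-type nitrogen and a carbonyl carbon. The steps at this position bear on it: a number 6.3 percentage points higher from compound 2 to compound 3 (within the scatter) was within the scatter, while a number 24.6 percentage points higher from compound 1 to compound 3 (beyond the scatter) was a modest gain on removing a larger side chain. A larger side chain now enters, so a modest decrease in this assay is expected, with wide uncertainty since no sulfur-bearing chain has been measured. For compound 4 the estimate is 40%, range 20% to 60%, expected as a number 13 percentage points lower from compound 3 to compound 4 (beyond the scatter).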

Compound 4, a percentage reported as activity, at one dose (the size of the read-out at that dose, not a potency): 41%
Beside the measured number, compound 4's estimate is 1 percentage points below it; measured number inside the range.
By their numbers in this assay, from the lowest: compound 1; then compounds 4, 2 and 3 (each within the scatter of the next, the first and the last beyond it).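

In this assay, the 2-(methylsulfanyl)ethyl chain gives up part of the read-out of the methyl compound (a number 12 percentage points lower from compound 3 to compound 4 (beyond the scatter)) yet stands clear of the 1-hydroxyethyl compound (a number 12.6 percentage points higher from compound 1 to compound 4 (beyond the scatter)), so chain length alone does not order this position, with compound 1 going against such a trend. Exchanging hydroxy for (methylsulfanyl)methyl stays within the scatter (a number 5.7 percentage points lower from compound 2 to compound 4 (within the scatter)). Nothing available explains these steps. Going by these compounds, whether the sulfur matters remains open: an all-carbon butyl chain would separate it from chain length, and a terminal amine or carboxylic acid would test other chain ends.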